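The source may hold more compounds than are shown below. What is called first, only, known or untested is meant among the compounds shown, and "the series" means these compounds.

Working notes on the series.

Two compounds sharing the same core have numbers in a functional assay on HCT-116 cells (Homo sapiens) for inhibition, read by sulforhodamine B assay, with a stated time of 48 h, tested at 50 uM (on this read-out lower numbers stand for less inhibition of growth and higher numbers for more inhibition of growth at the one concentration tested), so far. Compound 1 `COc1ccc(/C=C/C(=O)/C=C/c2ccc(OCc3cn(CCCCCOc4cc(=O)oc5ccccc45)nn3)c(OC)c2)cc1` gives 35% in this assay. Compound 2 `COc1ccc(/C=C/C(=O)/C=C/c2ccc(OCc3cn(CCOc4cc(=O)oc5ccccc45)nn3)c(OC)c2)cc1` gives 71% in this assay, the highest of the two numbers, and its nearest neighbour, compound 1, stands a good way lower, a gap beyond the scatter.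

The next compound is compound 3 `COc1cc(/C=C/C(=O)/C=C/c2ccco2)ccc1OCc1cn(CCOc2cc(=O)oc3ccccc23)nn1`. It differs from compound 2 in one place: furan-2-yl in place of 4-methoxyphenyl on a double-bonded chain carbon bound to a double-bonded chain carbon. Among the compounds with values here, no step between measured compounds covers this change, so the expectation rests on compound 2 alone. The step from compound 2 to compound 3 in this assay is expected to be a number 11 percentage points lower from compound 2 to compound 3 (beyond the scatter), a modest move downward that may well stay within the scatter. Compound 3 is accordingly estimated to give about 60% in this assay, with a range from 40% to 80%.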

Compound 3, percent growth inhibition at one concentration: 72%
Beside the measured number, compound 3's estimate is 12 percentage points below it; low and high end bracket the measured number.
By their numbers in this assay, from the lowest: compound 1; then compounds 2 and 3 (each within the scatter of the next).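

Until now this place, on a double-bonded chain carbon bound to a double-bonded chain carbon, had carried only 4-methoxyphenyl. In this assay, furan-2-yl in place of 4-methoxyphenyl gives a number 1 percentage points higher from compound 2 to compound 3 (within the scatter), so a five-membered aromatic ring with 1 hetero atom and 5 heavy atoms stands level with a six-membered aromatic ring of carbon only and 8 heavy atoms. Nothing at hand explains this outcome.

From the compounds shown here alone, it remains open whether thiophen-2-yl, a ring carrying an amine such as 4-(dimethylamino)phenyl, or a saturated group such as cyclohexyl would also stay within the scatter of compound 2. Also open, going by these compounds, is whether furan-2-yl gives the same result on the longer chain of compound 1, and whether compounds 2 and 3 stay level at other concentrations.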